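This account rests on a few compounds, and the source may have more. Where it says the series, first, only, none or still open, it means among the compounds named here.

Measured in a functional assay on the whole organism for antagonist activity, with Mus musculus as the target; a lower number here means that less compound is needed, a higher number that more compound is needed for the effect:
compound 1 `CCC(=O)N(c1ccc(Cl)c(Cl)c1)C1CCCC1O`: 9 mg/kg
compound 2 `CCCN(CCC)C1CCCC1N(C(=O)CC)c1ccc(Cl)c(Cl)c1`: 0.1 mg/kg
compound 3 `C=CCN(C)C1CCCC1N(C(=O)CC)c1ccc(Cl)c(Cl)c1`: 0.2 mg/kg

Compound 3, at 0.2 mg/kg, lies within the scatter of compound 2 and far below compound 1. The next compound is compound 4 `CCC(=O)N(c1ccc(Cl)c(Cl)c1)C1CCCC1N(C)Cc1ccccc1`, which turns the allyl group of compound 3 into a benzyl group: phenyl in place of vinyl on a saturated chain carbon bound to an amine nitrogen. Two steps show how much the amino group matters, a 90-fold lower number from compound 1 to compound 2 (1.95 log units; beyond the scatter) and a 45-fold lower number from compound 1 to compound 3 (1.65 log units; beyond the scatter), both replacing hydroxy. Compound 4 keeps an amine. The closest comparison is a 2.0-fold higher number from compound 2 to compound 3 (0.30 log units; within the scatter), a swap between amines that stayed within the scatter. Among the compounds with values here, no measured step introduces a phenyl, so some uncertainty remains. In this assay the expected change is small: a 1.5-fold higher number from compound 3 to compound 4 (0.18 log units; within the scatter). The estimate for compound 4 is 0.3 mg/kg, with an expected range of 0.1 mg/kg to 1 mg/kg.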

Compound 4, dose for half-maximal effect: 40 mg/kg
Compound 4: the middle estimate sits 130-fold (2.12 log units) below what was measured; measured number outside the range, above it.
By their numbers in this assay, from the lowest: compounds 2 and 3 (each within the scatter of the next); then compound 1; then compound 4.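

In this assay an amine on this ring carbon does not guarantee a low number: the benzyl group gives a large rise against the allyl group (a 200-fold higher number from compound 3 to compound 4 (2.30 log units; beyond the scatter)) and against dipropylamino (a 400-fold higher number from compound 2 to compound 4 (2.60 log units; beyond the scatter)). The group on the amine nitrogen therefore matters greatly here, since phenyl in place of vinyl undoes the whole gain seen with the other amines. Even the hydroxy compound needs less (a 4.4-fold higher number from compound 1 to compound 4 (0.65 log units; beyond the scatter)). No evidence at hand explains this jump. On these data alone, whether a cyclohexyl group in place of phenyl, or a longer chain carrying the phenyl, would behave the same stays open.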